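Swapping the aryl group on the triazole in two series

The compounds below may be only part of what the source reports. "The series", "measured", "known", "first", "only" and "open" are said of these compounds alone.

Compound 1 `CC(C)=CCC/C(C)=C/CC/C(C)=C/CC[C@@H]1[C@@]2(C)CC/C(=N\OCc3cn(-c4ccc(F)c(Cl)c4)nn3)C(C)(C)[C@@H]2CC[C@@]1(C)O` and compound 2 `CC(C)=CCC/C(C)=C/CC/C(C)=C/CC[C@@H]1[C@@]2(C)CC/C(=N\OCc3cn(-c4c(Cl)cc([N+](=O)[O-])cc4Cl)nn3)C(C)(C)[C@@H]2CC[C@@]1(C)O` share one core and differ only in the group carried on the triazole nitrogen. In a functional assay on MCF7 cells (Homo sapiens) for cytotoxicity, read by MTT assay, with a stated time of 48 h (on this read-out higher numbers stand for weaker inhibition and lower numbers for stronger inhibition), compound 1 gives 31400 nM, and compound 2 gives 16600 nM. The step between them is a 1.9-fold lower number from compound 1 to compound 2 (0.28 log units; within the scatter).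

Compound 3 `CC(C)=CCC/C(C)=C/CC/C(C)=C/CC[C@@H]1[C@@]2(C)C/C(=C\c3ccc(OCc4cn(-c5ccc(F)c(Cl)c5)nn4)cc3)C(=O)C(C)(C)[C@@H]2CC[C@@]1(C)O` carries the same 3-chloro-4-fluorophenyl group on a different core; the difference between the two cores is not broken down here. In this assay, among the compounds with values here, compound 3 gives 46500 nM, a number that lies within the scatter of the one for compound 1 but stands higher than the one for compound 2, beyond the scatter.

Compound 4 `CC(C)=CCC/C(C)=C/CC/C(C)=C/CC[C@@H]1[C@@]2(C)C/C(=C\c3ccc(OCc4cn(-c5c(Cl)cc([N+](=O)[O-])cc5Cl)nn4)cc3)C(=O)C(C)(C)[C@@H]2CC[C@@]1(C)O` has not yet been measured. It relates to compound 3 exactly as compound 2 relates to compound 1: 2,6-dichloro-4-nitrophenyl in place of 3-chloro-4-fluorophenyl on an aromatic nitrogen. The surroundings of the change are the same in both pairs, so it is the same change. Resting on the step of a 1.9-fold lower number from compound 1 to compound 2 (0.28 log units; within the scatter), which stayed within the scatter, a step of similar modest size is expected here: a 1.9-fold lower number from compound 3 to compound 4 (0.27 log units; within the scatter). Compound 4 is therefore estimated at 25000 nM in this assay, with an expected range from 12000 nM to 50000 nM.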

Compound 4, half-maximal inhibitory concentration: 27100 nM
Beside the measured number, compound 4's estimate is 1.1-fold (0.04 log units) below it; the range from low to high includes it.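

On the second core, the swap to 2,6-dichloro-4-nitrophenyl gives a 1.7-fold lower number from compound 3 to compound 4 (0.23 log units; within the scatter) in this assay. Set beside the same swap on the first core, the two steps agree in size: the same change on two cores in this assay, a 1.9-fold lower number (0.28 log units; within the scatter) from compound 1 to compound 2 and a 1.7-fold lower number (0.23 log units; within the scatter) from compound 3 to compound 4, 1.1-fold (0.04 log units) apart, within the scatter of two such steps. This shows that the change behaved alike on the two cores shown, but each step lies within the scatter on its own, so the pairs do not establish that the swap makes any real difference to the number, and two cores cannot show that the agreement would hold on a third.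

The compounds shown leave open what the parts of the entering group do separately, since the nitro group and the two chlorine atoms arrive together, and a simple 4-nitrophenyl or 2,6-dichlorophenyl would pull them apart. They also leave open whether a group of another kind on the ring nitrogen, such as a benzyl or a plain alkyl chain, would give a step beyond the scatter.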